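Chloro to fluoro in a level pair

The compounds below may be only part of what the source reports. "The series", "measured", "known", "first", "only" and "open" are said of these compounds alone.

Among the compounds with values here, in a functional assay on HeLa cells (Homo sapiens) for inhibition, read by MTT assay, with a stated time of 72 h (on this read-out lower numbers stand for stronger inhibition and higher numbers for weaker inhibition), compound 1 `Cc1ccc(-c2nnc(SCCCN3CCN(c4nc5ccccc5s4)CC3)o2)cc1` gives 179000 nM and compound 2 `Clc1ccc(-c2nnc(SCCCN3CCN(c4nc5ccccc5s4)CC3)o2)cc1` gives 177000 nM, so compound 2 stands level with the only other measured compound. Compound 3 `Fc1ccc(-c2nnc(SCCCN3CCN(c4nc5ccccc5s4)CC3)o2)cc1` differs from compound 2 in one group: fluoro in place of chloro on an aromatic carbon. Within the data shown here, one measured step bears on this, chloro in place of methyl on an aromatic carbon, and it amounts to a 1.0-fold lower number from compound 1 to compound 2 (0.00 log units; within the scatter). No step beyond the scatter is therefore expected in this assay. The estimated step is a 1.0-fold lower number from compound 2 to compound 3 (0.00 log units; within the scatter). Compound 3 is expected at 175000 nM, with an estimated range from 95000 nM to 300000 nM.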

Compound 3, half-maximal inhibitory concentration: 134000 nM
Beside the measured number, compound 3's estimate is 1.3-fold (0.12 log units) above it, within the range that was stated.
By their numbers in this assay, from the lowest: compounds 3, 2 and 1 (each within the scatter of the next).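

Fluoro in place of chloro gives (a 1.3-fold lower number from compound 2 to compound 3 (0.12 log units; within the scatter)) and fluoro in place of methyl gives ((a 1.3-fold lower number from compound 1 to compound 3 (0.13 log units; within the scatter))). Methyl, chloro and fluoro on this aromatic carbon, para to a large group, therefore all read as level in this assay, so this small change has not separated the three compounds. No evidence is available to explain this level reading. Still open, as far as these compounds go, is whether an amine, a carboxylic acid or a longer chain at this position would move the number beyond the scatter.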